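Replacing fluoro with methoxymethoxy in compound 2

The compounds below may be only part of what the source reports. "The series", "measured", "known", "first", "only" and "open" are said of these compounds alone.

- compound 1 `CCOc1ccc(C[S+]([O-])c2ncccc2C(=O)Nc2ccncc2)c(OCC)c1` reads 0.49 h
- compound 2 `COc1ccc(C[S+]([O-])c2ncccc2C(=O)Nc2ccncc2)c(OCCF)c1` reads 3.3 h
- compound 3 `COc1cc(OC)c(C[S+]([O-])c2ncccc2C(=O)Nc2ccncc2)c(OC)c1` reads < 0.03 h as a limit of the assay

In an ADME assay (on this read-out higher numbers stand for a longer-lived compound and lower numbers for a shorter-lived compound), compound 2 gives 3.3 h and so holds the higher of the two numbers, with compound 1 at 0.49 h lower by a gap beyond the usual scatter. Compound 3 gives < 0.03 h which is a limit of the assay and not a number.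

Compound 4 `COCOCCOc1cc(OC)ccc1C[S+]([O-])c1ncccc1C(=O)Nc1ccncc1` has not yet been measured and differs from compound 2 in one place, methoxymethoxy in place of fluoro on a saturated chain carbon, two bonds along the chain from an oxygen on an aromatic ring and the same change reads 2-fluoroethoxy to 2-(methoxymethoxy)ethoxy. Within the data shown here, no measured pair differs in one place only, so no step size for this change can be read from the data. Compound 2 at 3.3 h is the highest number here, and compound 1 at 0.49 h shows how much lower a related structure can sit, so a fall is the more likely direction. The expected change is a 5.5-fold lower number from compound 2 to compound 4 (0.74 log units; beyond the scatter) and it is expected to lie beyond the scatter. Compound 4 is estimated at 0.6 h with an expected range from 0.15 h to 2 h on this reasoning.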

Compound 4, half-life: 2.75 h
Compound 4: middle estimate off by 4.6-fold (0.66 log units), on the low side, and the stated range ends below it.
By their numbers in this assay, from the lowest: compound 1; then compounds 4 and 2 (each within the scatter of the next). At a limit, below all of these: compound 3.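

In this assay, methoxymethoxy in place of fluoro on a saturated chain carbon, two bonds along the chain from an oxygen on an aromatic ring, gives a 1.2-fold lower number from compound 2 to compound 4 (0.08 log units; within the scatter) and so stays within the scatter. Among these compounds, this is the first change in one place that can be read at this position, and it shows that a group of 4 heavy atoms with 2 hydrogen-bond acceptors can replace a single fluorine with no difference this read-out can resolve. Nothing in the data shown bears on why the two compounds read alike.

As far as these compounds go, whether the same holds for an amine, a carboxylic acid or a longer chain at this chain end stays open. Steps to compound 1 and compound 3 cannot be read, since each differs from compound 2 in more than one place, so the part played by the other groups on the shared core also stays open.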